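The source may hold more compounds than are shown below. What is called first, only, known or untested is meant among the compounds shown, and "the series" means these compounds.

In a functional assay on Bel-7402 cells (Homo sapiens) for cytotoxicity, read by MTT assay, with a stated time of 48 h (a higher number here means a weaker inhibitor, a lower number a stronger inhibitor), compound 1 (`CCn1cc(-c2nc3ccccc3[nH]2)c(=O)c2cc(F)c(N3CCNCC3)nc21`) gives 4100 nM and stands among three measured compounds. Compound 2 (`CCn1cc(-c2nc3ccccc3o2)c(=O)c2cc(F)c(N3CCNC(C)C3)c(F)c21`) gives 5700 nM in this assay, a number within the scatter of that of compound 1. Compound 3 (`CCn1cc(-c2nc3ccccc3o2)c(=O)c2cc(F)c(N3CCN(C)CC3)cc21`) gives 2000 nM in the same read-out, a lower number than that of compound 1 and beyond the scatter. Compound 1 therefore sits close to compound 2 and apart from compound 3. For the measured compounds named here, neither of these two neighbours differs from compound 1 in a single place, so no measured pair shows the effect of a one-place change here.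

Compound 4 (`CCn1cc(-c2nc3ccccc3s2)c(=O)c2cc(F)c(N3CCNCC3)nc21`) carries 1,3-benzothiazol-2-yl in place of 1H-benzimidazol-2-yl on an aromatic carbon of the core of compound 1. The counted change is 1,3-benzothiazol-2-yl in place of 1H-benzimidazol-2-yl on an aromatic carbon and the rest of the structure stays the same. Going by the values given here, with no measured step to guide the estimate, the anchor is compound 1 at 4100 nM and the expectation is only a small move toward a lower number. The expected step is a 1.4-fold lower number from compound 1 to compound 4 (0.14 log units; within the scatter) and it is estimated to remain within the scatter. For compound 4 the estimated value is 3000 nM with an expected range from 1000 nM to 9000 nM in this measurement.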

Compound 4, half-maximal inhibitory concentration: 2400 nM
Compound 4: the middle estimate sits 1.3-fold (0.10 log units) above what was measured, and the stated range covers the measured number.
By their numbers in this assay, from the lowest: compounds 3, 4, 1 and 2 (each within the scatter of the next, the first and the last beyond it).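

For the compounds shown here, this is the first pair in the set that differs in one place, and it gives a direct reading at this aromatic carbon of the core of compound 1. In this assay, 1,3-benzothiazol-2-yl in place of 1H-benzimidazol-2-yl gives a 1.7-fold lower number from compound 1 to compound 4 (0.23 log units; within the scatter), so the two compounds cannot be told apart, and this exchange of one fused two-ring group for another of the same heavy-atom count leaves the number within the scatter, even though the hydrogen-bond donor counted on 1H-benzimidazol-2-yl is gone and a sulfur has entered. No measurement of any property of these two groups bears on this result, so the pair offers no account of it.

The compounds shown leave open whether a group of a different kind on this aromatic carbon, such as a carboxylic acid or a plain phenyl ring, would move the number beyond the scatter of compound 1. They also leave open how 1,3-benzoxazol-2-yl compares with these two groups, since it appears here only in compounds that differ from them in other places as well.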